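Alpha-ketooxazole series: aryl replacement at the oxazole carbon

This account rests on a few compounds, and the source may have more. Where it says the series, first, only, none or still open, it means among the compounds named here.

Three compounds of this series have numbers in an assay (Rattus norvegicus) for inhibition of Fatty-acid amide hydrolase 1 (Homo sapiens); on this read-out lower numbers stand for stronger inhibition and higher numbers for weaker inhibition. Compound 1 `NS(=O)(=O)c1ccccc1-c1cnc(C(=O)CCCCCCc2ccccc2)o1` gives 1500 nM. Compound 2 `O=C(CCCCCCc1ccccc1)c1ncc(-c2cccc(C(=O)C(F)(F)F)c2)o1` gives 16 nM. Compound 3 `O=C(CCCCCCc1ccccc1)c1ncc(-c2ccc([N+](=O)[O-])cc2)o1` gives 50 nM, which stands second highest of the three: compound 2 shows a lower number and the gap lies beyond the scatter, while compound 1 shows a much higher number, also beyond the scatter. All three share the same core and differ only in the aromatic group on the five-membered ring.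

Compound 4 `Cc1cccc(-c2cnc(C(=O)CCCCCCc3ccccc3)o2)n1` is not yet measured in this assay. Compared with compound 3 the change is 6-methylpyridin-2-yl in place of 4-nitrophenyl on an aromatic carbon. Going by the values given here, no step between measured compounds resembles this exchange, so the direction cannot be read from the data directly. Because the aromatic groups of compound 2 16 nM and compound 3 50 nM both keep the number low, a similar outcome is expected here. The step from compound 3 to compound 4 is expected to be a 1.3-fold lower number from compound 3 to compound 4 (0.10 log units; within the scatter), not beyond the scatter. Compound 4 is estimated at 40 nM, within 12 nM to 130 nM.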

Compound 4, inhibition constant: 3.3 nM
Compound 4: middle estimate off by 12-fold (1.08 log units), on the high side; measured number below the stated range.
By their numbers in this assay, from the lowest: compound 4; then compound 2; then compound 3; then compound 1.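

Notes on the position next to the ring oxygen: in this assay the 6-methylpyridin-2-yl group in place of 4-nitrophenyl gives a 15-fold lower number from compound 3 to compound 4 (1.18 log units; beyond the scatter) and so counts as a large step beyond the scatter. Going by these compounds alone, the earlier compounds carried only aromatic rings of carbon, so this is the first sign that a ring with a hetero atom at this position can give a low number, and compound 4 at 3.3 nM now has the lowest number. Within the data shown here, no measurement on hand bears on why this exchange moves the number so far.

The ring nitrogen and the methyl group enter together, so this step does not separate them. From the compounds shown here alone, whether plain pyridin-2-yl without the methyl, or a carboxylic acid on the pyridine ring, keeps the number this low remains open.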